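Oxytocin receptor binding: pyridine isomer swap with methylamide terminus

The source may report more compounds than this note shows. Statements on the series, on what has been measured and on what is new or still open speak of the compounds shown alone.

Measured compounds:
compound 1 `CC[C@H](C)[C@@H]1C(=O)N[C@H](C2Cc3ccccc3C2)C(=O)N1[C@@H](C(=O)N1CCOCC1)c1cnc(C)cc1C` — 0.0501 nM
compound 2 `CC[C@H](C)[C@@H]1C(=O)N[C@H](C2Cc3ccccc3C2)C(=O)N1[C@@H](C(=O)N(C)C)c1cnc(C)cc1C` — 0.0398 nM
compound 3 `CC[C@H](C)[C@@H]1C(=O)N[C@H](C2Cc3ccccc3C2)C(=O)N1[C@@H](C(=O)NC)c1cc(C)cnc1C` — 1.26 nM

In an assay on isolated protein for displacement of a labelled ligand from Oxytocin receptor (Homo sapiens) (on this read-out higher numbers stand for weaker inhibition and lower numbers for stronger inhibition), compound 3 gives the highest of the three numbers; compound 1 and compound 2 sit well below it, beyond the scatter. Within the data shown here, the only single-place step measured, a 1.3-fold lower number from compound 1 to compound 2 (0.10 log units; within the scatter), lies within the scatter, so the amide terminus does not move the number here.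

Compound 4 `CC[C@H](C)[C@@H]1C(=O)N[C@H](C2Cc3ccccc3C2)C(=O)N1[C@@H](C(=O)NC)c1cnc(C)cc1C` is not yet measured. Relative to compound 3 the change is 4,6-dimethylpyridin-3-yl in place of 2,5-dimethylpyridin-3-yl on a saturated chain carbon bound to an amide-type nitrogen in a ring and a carbonyl carbon. Among the measured compounds shown here, no measured pair differs in this place alone, so the step has no direct precedent. What the values show is that compound 1 and compound 2, both carrying 4,6-dimethylpyridin-3-yl, sit far below compound 3, while the amide change from compound 1 to compound 2 is within the scatter; the gap between compound 3 and compound 1 may therefore largely reflect the pyridine. A clear drop in this assay is expected for compound 4, of about a 13-fold lower number from compound 3 to compound 4 (1.10 log units; beyond the scatter). The estimate for compound 4 is 0.1 nM, with a range of 0.03 nM to 0.5 nM.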

Compound 4, inhibition constant: 0.0631 nM
For compound 4 the middle estimate is 1.6-fold (0.20 log units) above the measured one; low and high end bracket the measured number.
By their numbers in this assay, from the lowest: compounds 2, 1 and 4 (each within the scatter of the next); then compound 3.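

In this assay the pyridine now has a direct single-place comparison on the saturated chain carbon: 4,6-dimethylpyridin-3-yl in place of 2,5-dimethylpyridin-3-yl gives a 20-fold lower number from compound 3 to compound 4 (1.30 log units; beyond the scatter), although the two groups hold the same atoms, joined differently. With 4,6-dimethylpyridin-3-yl held fixed, the amide terminus stays within the scatter for methylamino as well, with a 1.6-fold higher number from compound 2 to compound 4 (0.20 log units; within the scatter) and a 1.3-fold higher number from compound 1 to compound 4 (0.10 log units; within the scatter), so the earlier gap of compound 3 to compound 1 and compound 2 fits the pyridine change. No data on hand explain the size of this step.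

On these data alone, whether the amide terminus is equally tolerated with 2,5-dimethylpyridin-3-yl remains open, as compound 3 alone carries that group. Also open, as far as these compounds go, is how an unsubstituted pyridin-3-yl, or a carboxylic acid in place of the amide, would read in this assay.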